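What a nitro group may do to compound 3

A few compounds are considered here, and "the series" means these few. Any claim that something is new, unique, unknown or untested is made for them only; others in the source may bear on it.

In a functional assay on HT-1080 cells (Homo sapiens) for antiproliferative activity, read by MTT assay, with a stated time of 72 h (on this read-out higher numbers stand for weaker inhibition and lower numbers for stronger inhibition), compound 3 (`COc1ccc(-c2ccsc2-c2cc(OC)c(OC)c(OC)c2)cc1`) stands lowest at 3620 nM of the three numbers. On the same read-out compound 1 (`CCOC(=O)c1cc(-c2ccc(OC)c([N+](=O)[O-])c2)c(-c2cc(OC)c(OC)c(OC)c2)s1`) gives 26100 nM and compound 2 (`COc1ccc(-c2cc(C(=O)O)sc2-c2cc(OC)c(OC)c(OC)c2)cc1[N+](=O)[O-]`) gives 38100 nM. The gaps from both of them to compound 3 lie beyond the scatter. The change to compound 4 (`COc1ccc(-c2ccsc2-c2cc(OC)c(OC)c(OC)c2)cc1[N+](=O)[O-]`) is nitro in place of hydrogen on an aromatic carbon of a six-membered aromatic ring of carbon only, ortho to a methoxy group and meta to a large group (nitro in place of hydrogen on an aromatic carbon). For the measured compounds named here, no measured step covers this change directly. Going by the values given here, the one step available (a 1.5-fold higher number from compound 1 to compound 2 (0.16 log units; within the scatter)) puts hydrogen in place of ethyl elsewhere in the molecule and stays within the scatter, so it offers little guidance here. Compound 1 and compound 2 both carry the nitro group and both sit well above compound 3, but they also carry a carbonyl group that compound 3 lacks, so their gap cannot be credited to the nitro group alone. A moderate upward move in this assay is therefore expected, smaller than that gap. The expected size is an estimate resting on thin evidence (a 2.2-fold higher number from compound 3 to compound 4 (0.34 log units; beyond the scatter)). Compound 4 is estimated at 8000 nM in this read-out, and is expected to fall between 1800 nM and 30000 nM on repeated measurement.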

Compound 4, half-maximal inhibitory concentration: 8040 nM
Beside the measured number, compound 4's estimate is 1.0-fold (0.00 log units) below it, within the range that was stated.
By their numbers in this assay, from the lowest: compound 3; then compound 4; then compounds 1 and 2 (each within the scatter of the next).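

In this assay the nitro group now has a direct reading of its own: placed on an aromatic carbon, ortho to a methoxy group and meta to a large group, it gives a 2.2-fold higher number from compound 3 to compound 4 (0.35 log units; beyond the scatter) and thus moves the number upward on the otherwise unchanged core. Compound 4 also shows that the carboxy and ethoxycarbonyl groups have steps of their own with the nitro group held in place, since hydrogen in place of carboxy gives a 4.7-fold lower number from compound 2 to compound 4 (0.68 log units; beyond the scatter) and hydrogen in place of ethoxycarbonyl gives a 3.2-fold lower number from compound 1 to compound 4 (0.51 log units; beyond the scatter) in the same read-out. No measurement at hand accounts for the size or direction of any of these steps.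

The compounds shown leave open whether this upward step belongs to the nitro group in particular or would also appear with an amine, a chlorine or a nitrile on the same aromatic carbon. They also leave open how a hydroxy group in place of the methoxy group would read with the nitro group present, and whether an amide in place of the carboxy group would follow the same course.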